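The compounds below may be only part of what the source reports. "The series", "measured", "known", "first", "only" and "open" are said of these compounds alone.

Measured so far in an assay on ileum (strain Hartley) with 5-hydroxytryptamine receptor 3A (Cavia porcellus) as the target; on this read-out higher numbers stand for larger maximal responses and lower numbers for smaller maximal responses:

compound 1, `CN1CCN(c2nc3cccc(Cl)c3o2)CC1`, 0.24
compound 2, `COc1ccc2oc(N3CCN(C)CC3)nc2c1`, 0.78
compound 3, `CCc1cc(Cl)cc2nc(N3CCN(C)CC3)oc12`, 0.17

Compound 2 stands highest of the three numbers in this assay. Its nearest neighbour is compound 1, whose value lies lower by a margin beyond the usual scatter, and furthest from it is compound 3, lower still and likewise beyond the scatter. Among the compounds with values here, none of these three pairs differs in a single place, so no measured step is known for any one change.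

Compound 4, `CN1CCN(c2nc3cc(Br)ccc3o2)CC1`, has not yet been measured in this assay. It differs from compound 2 in one place: bromo in place of methoxy on an aromatic carbon. Within the data shown here, no pair among the measured compounds shows what this change does, so the expectation rests only on what the three values show. The two compounds carrying a halogen on the shared core, compound 1 with 0.24 and compound 3 with 0.17, both sit far below compound 2. On that basis compound 4 is expected to fall from compound 2 by a step beyond the scatter, a number 0.43 lower from compound 2 to compound 4 (beyond the scatter), in the downward direction. The value estimated for compound 4 in this assay is 0.35, within a range from 0.15 to 0.6.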

Compound 4, intrinsic activity: the largest response reached, as a fraction of the reference agonist's: 0.48
Estimate against measurement, compound 4: 0.13 below; the range from low to high includes it.
By their numbers in this assay, from the lowest: compounds 3 and 1 (each within the scatter of the next); then compound 4; then compound 2.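

In this assay, bromo in place of methoxy on an aromatic carbon, meta to a fused ring and para to a fused ring, gives a number 0.30 lower from compound 2 to compound 4 (beyond the scatter). Within the data shown here, this is the first single change on the shared core with a measured outcome, and it shows that the group at this place bears on the maximal response. The step also shows that a methoxy, with its two heavy atoms and one hydrogen-bond acceptor, can give way to a bromo, with one heavy atom and no acceptor, while compound 4 still reaches 0.48, but nothing at hand accounts for the fall, and the data cannot separate the loss of the acceptor from the other differences between the two groups.

The compounds shown leave open whether the response at this place follows the hydrogen-bond acceptor count or depends on the particular groups compared, which a hydroxyl, an amine or a longer chain such as propoxy at the same carbon would help to tell. They also leave open whether this step would keep its direction and size on a core carrying a second substituent on the six-membered aromatic ring.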